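From 4-methoxybenzyl to propyl

This account rests on a few compounds, and the source may have more. Where it says the series, first, only, none or still open, it means among the compounds named here.

In a functional assay on MGC-803 cells (Homo sapiens) for inhibition, read by MTT assay, with a stated time of 72 h (on this read-out higher numbers stand for weaker inhibition and lower numbers for stronger inhibition), compound 3 (`COc1ccc(CSc2nc3nc(C)cc(Nc4cc(-c5ccccc5)[nH]n4)n3n2)cc1`) gives 3170 nM. Compound 1 (`Cc1cc(Nc2cc(-c3ccccc3)[nH]n2)n2nc(SCc3ccc(F)cc3)nc2n1`) gives 3270 nM, and the data show a 1.0-fold lower number from compound 1 to compound 3 (0.01 log units; within the scatter), so these two sit level at the low end of the three numbers. Compound 2 (`C=CCSc1nc2nc(C)cc(Nc3cc(-c4ccccc4)[nH]n3)n2n1`) stands clear of both at 17200 nM.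

Compound 4 (`CCCSc1nc2nc(C)cc(Nc3cc(-c4ccccc4)[nH]n3)n2n1`) alters compound 3 in one place: ethyl in place of 4-methoxyphenyl on a saturated chain carbon bound to a sulfur.

The measured steps that bear on this change the same place. One is a 5.4-fold lower number from compound 2 to compound 3 (0.73 log units; beyond the scatter), where 4-methoxyphenyl replaces vinyl. The other is a 5.3-fold higher number from compound 1 to compound 2 (0.72 log units; beyond the scatter), where vinyl replaces 4-fluorophenyl. Ethyl, like the vinyl of compound 2, carries no ring, so compound 4 is expected to land near compound 2 rather than near compound 3. The expected change is a 4.7-fold higher number from compound 3 to compound 4 (0.68 log units; beyond the scatter), a modest step towards weaker inhibition. For compound 4 the estimate is 15000 nM, with an expected range of 7000 nM to 32000 nM.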

Compound 4, half-maximal inhibitory concentration: 12600 nM
Estimate against measurement, compound 4: 1.2-fold (0.08 log units) above, and the stated range covers the measured number.
By their numbers in this assay, from the lowest: compounds 3 and 1 (each within the scatter of the next); then compounds 4 and 2 (each within the scatter of the next).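

Replacing the 4-methoxyphenyl with ethyl weakens inhibition in this assay (a 4.0-fold higher number from compound 3 to compound 4 (0.60 log units; beyond the scatter)), and the step from the 4-fluorophenyl compound is of like size (a 3.9-fold higher number from compound 1 to compound 4 (0.59 log units; beyond the scatter)). Ethyl and vinyl, by contrast, cannot be told apart (a 1.4-fold lower number from compound 2 to compound 4 (0.14 log units; within the scatter)), so the double bond of compound 2 is not what separates it from compounds 1 and 3, and all four compounds now fall into a ring-bearing pair with the lower numbers and a ring-free pair with the higher ones, with none going against this split. Nothing measured here gives a reason for that split.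

As far as these compounds go, whether a saturated ring such as cyclohexyl or a longer chain such as hexyl would read like the aromatic pair or the ring-free pair remains open. So does whether a carboxylic acid on the aromatic ring would keep the level of compound 3.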